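The source may report more compounds than this note shows. Statements on the series, on what has been measured and on what is new or still open speak of the compounds shown alone.

Working notes on the series, read in a physicochemical assay for solubility, read by chemiluminescence, measured as kinetic solubility; on this read-out higher numbers stand for higher solubility and lower numbers for lower solubility. Compound 3 (`COc1cccc2c1c(NS(=O)(=O)c1ccc(Cl)s1)nn2Cc1cccc(CNC(=O)C2CCCO2)c1`) gives >= 153 ug/mL, which is a limit and not a number. Compound 1 (`CC(=O)NCc1cccc(Cn2nc(NS(=O)(=O)c3ccc(Cl)s3)c3c(C(C)O)cccc32)c1`) gives >= 208 ug/mL, also a limit. Compound 2 (`CC(=O)NCc1cccc(Cn2nc(NS(=O)(=O)c3ccc(Cl)s3)c3c(C(C)(C)O)cccc32)c1`) gives >= 159 ug/mL, again a limit. All the values in hand are therefore limits, and no order can be read among these compounds.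

The next compound is compound 4 (`COc1cccc2c1c(NS(=O)(=O)c1ccc(Cl)s1)nn2Cc1cccc(CNC2COC2)c1`), which has oxetan-3-yl in place of (oxolan-2-yl)carbonyl on an amine nitrogen.

Among the compounds with values here, only one measured step exists, a step that the two limits leave unreadable from compound 1 to compound 2. It puts a methyl in place of hydrogen on a saturated chain carbon and leaves the group on the amine nitrogen untouched, so it does not bear directly on this change and offers no size to carry over. Within the data shown here, no measured step covers the exchange of these two groups. The expectation therefore rests on compound 3 alone, and no step beyond the scatter is expected in either direction. In this assay the expected step is an at least 1.0-fold lower number from compound 3 to compound 4 (0.00 log units; that floor lies within the scatter). For compound 4 the estimated value is 150 ug/mL, with an expected range from 70 ug/mL to 220 ug/mL.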

Compound 4, solubility: 122 ug/mL
Compound 4: middle estimate off by 1.2-fold (0.09 log units), on the high side; low and high end bracket the measured number.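

In this assay, within the data shown here, compound 4 is the first compound of the series to give a number and not a limit, so this position now has one readable anchor. Oxetan-3-yl in place of (oxolan-2-yl)carbonyl on an amine nitrogen gives an at least 1.2-fold lower number from compound 3 to compound 4 (0.09 log units; that floor lies within the scatter), and the change thus has a floor, which no earlier pair of compounds provided. Only that floor can be read, and the full size of the step stays unknown, because the value of compound 3 is a limit: the limit of >= 153 ug/mL in this assay, at which 1 of the 4 values shown sits.

The compounds shown do not separate loss of the carbonyl from the exchange of the five-membered ring for the four-membered ring, and the step from compound 1 to compound 2 cannot be read either. From the compounds shown here alone, it also stays open how a simple alkyl chain, a longer chain ending in a carboxylic acid, or a plain acetyl group on the same nitrogen would read against compound 4, which now offers a number to compare with.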